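The source may hold more compounds than are shown below. What is called first, only, known or untested is meant among the compounds shown, and "the series" means these compounds.

Compound 1 `Cc1ccccc1N/C(=N\C#N)N1CCN(C(=O)Cc2ccsc2)C(c2ccccc2)C1`, compound 2 `Cc1ccccc1N/C(=N\C#N)N1CCN(C(=O)Cn2nccc2C)C(c2ccccc2)C1`.

In a functional assay for antagonist activity at P2X purinoceptor 7 (Homo sapiens), read by FLIPR and calcium flux (a higher number here means a weaker inhibitor, a lower number a stronger inhibitor), compound 1 gives 71 nM. In the same assay compound 2 gives 60 nM, the lowest of the two numbers, though only by a 1.2-fold lower number from compound 1 to compound 2 (0.07 log units; within the scatter), a gap within the scatter. Compound 3 `Cc1ccccc1N/C(=N\C#N)N1CCN(C(=O)Cc2cccs2)C(c2ccccc2)C1` differs from compound 2 by thiophen-2-yl in place of 5-methyl-1H-pyrazol-1-yl on a saturated chain carbon bound to a carbonyl carbon. For the measured compounds named here, the one measured step that bears on this, swapping a thiophene for the pyrazole at this position, was a 1.2-fold lower number from compound 1 to compound 2 (0.07 log units; within the scatter), which argues that the group here barely moves the number. Compound 3 is therefore expected to sit close to compound 2, a step of a 1.2-fold higher number from compound 2 to compound 3 (0.07 log units; within the scatter), with an estimated value of 70 nM and a range from 30 nM to 160 nM.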

Compound 3, half-maximal inhibitory concentration: 46 nM
Beside the measured number, compound 3's estimate is 1.5-fold (0.18 log units) above it; measured number inside the range.
By their numbers in this assay, from the lowest: compounds 3, 2 and 1 (each within the scatter of the next).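

In this assay, the thiophene can be attached either way with little effect: thiophen-2-yl in place of thiophen-3-yl gives (a 1.5-fold lower number from compound 1 to compound 3 (0.19 log units; within the scatter)), and thiophen-2-yl in place of 5-methyl-1H-pyrazol-1-yl gives (a 1.3-fold lower number from compound 2 to compound 3 (0.12 log units; within the scatter)). On this saturated chain carbon bound to a carbonyl carbon, three different five-membered aromatic rings, with one or two hetero atoms, therefore all give numbers within the scatter of one another. No measured evidence is available to explain these small differences. Still open, as far as these compounds go, is whether an amine, a carboxylic acid or a longer chain at this position would keep the number this close.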